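The source may hold more compounds than are shown below. What is called first, only, known or untested is meant among the compounds shown, and "the series" means these compounds.

Measured so far: compound 1 `CCCSc1nc(Nc2ccccc2)c2nc(Nc3ccccc3)sc2n1`, 24400 nM; compound 2 `CCCSc1nc(NCc2ccco2)c2nc(Nc3ccccc3)sc2n1`, > 64000 nM.

Within the data shown here, in a functional assay on MGC-803 cells (Homo sapiens) for antiproliferative activity, read by MTT assay, with a stated time of 72 h (on this read-out higher numbers stand for weaker inhibition and lower numbers for stronger inhibition), compound 1 gives 24400 nM, the only plain number among the values shown. Compound 2, with its value of > 64000 nM, sits at a limit of the assay, as the limit of > 64000 nM in this assay, at which 1 of the 2 values shown sits, records. Compound 3 `CCCSc1nc(NCc2ccc(O)cc2)c2nc(Nc3ccccc3)sc2n1` carries 4-hydroxybenzyl in place of phenyl on a nitrogen on an aromatic ring. Among the measured compounds shown here, the one measured step that bears on this change is an at least 2.6-fold higher number from compound 1 to compound 2 (0.41 log units; beyond the scatter), another replacement at that nitrogen, and it weakened inhibition. For compound 3 a comparable loss is therefore expected, a 2.0-fold higher number from compound 1 to compound 3 (0.31 log units; beyond the scatter). Compound 3 is estimated at 50000 nM, within 20000 nM to 150000 nM.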

Compound 3, half-maximal inhibitory concentration: 21900 nM
Estimate against measurement, compound 3: 2.3-fold (0.36 log units) above, within the range that was stated.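

In this assay the move to (4-hydroxybenzyl)amino in place of anilino (a 1.1-fold lower number from compound 1 to compound 3 (0.05 log units; within the scatter)) shows that a replacement at this nitrogen need not weaken inhibition. What sits on the saturated chain carbon counts, as 4-hydroxyphenyl in place of furan-2-yl shows (an at least 2.9-fold lower number from compound 2 to compound 3 (0.46 log units; beyond the scatter)). Compound 2 gives > 64000 nM and this is a limit and not a number, so that step is only a bound: the limit of > 64000 nM in this assay, at which 1 of the 3 values shown sits.

On these data alone, whether plain benzyl on this nitrogen would give the same level of inhibition stays open. So does the effect of a carboxylic acid in place of the hydroxy group.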